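Methyl on the phenyl end: expectation for compound 4

The compounds below may be only part of what the source reports. "The series", "measured", "known", "first", "only" and "open" are said of these compounds alone.

For the measured compounds named here, compound 2 `CCc1nc2ccccc2n1CCCCOc1ccccc1` stands as the only plain number in an ADME assay on Vero cells (Chlorocebus sabaeus) for cytotoxicity, read by luminescence, with a stated time of 2 days (a lower number here means that less compound is tolerated, a higher number that more compound is tolerated), at 21 uM. Compound 1 `CCc1nc2ccccc2n1CCCOc1ccccc1` reaches only the limit of the assay, > 50 uM. Compound 3 `Cc1nc2ccccc2n1CCCCOc1ccccc1` likewise sits at the limit, > 50 uM. Thus the limit of > 50 uM in this assay, at which 2 of the 3 values shown sit, holds for two of the three compounds, and compound 2 is the one member under it. Going by the values given here, the one step between measured neighbours, an at least 2.3-fold higher number from compound 2 to compound 3 (0.37 log units; beyond the scatter), removes the methyl from the chain carbon on the core and carries the number past the limit. Compound 1 and compound 2 differ in their chain; their values, a limit and a number, are all that can be said of that pair.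

Compound 4 `CCc1nc2ccccc2n1CCCCOc1cccc(C)c1` is compound 2 with methyl in place of hydrogen on an aromatic carbon. Among the compounds with values here, no measured step touches the six-membered aromatic ring of carbon only; the step from compound 2 to compound 3 concerns the chain carbon on the core and does not bear on a ring methyl. With nothing in the series pointing either way, the expectation in this assay is a step, a 1.3-fold lower number from compound 2 to compound 4 (0.12 log units; within the scatter), that stays within the scatter, in no definite direction. Compound 4 is therefore estimated at 16 uM, with a range of 5 uM to 50 uM.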

Compound 4, half-maximal toxic concentration: 19 uM
Compound 4: the middle estimate sits 1.2-fold (0.07 log units) below what was measured; the range from low to high includes it.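

In this assay, for the compounds shown here, the first change on the phenyl end, phenyl to 3-methylphenyl, gives a 1.1-fold lower number from compound 2 to compound 4 (0.04 log units; within the scatter), so a methyl on this aromatic carbon, meta to a large group, leaves compound 4 level with compound 2 within the scatter. Going by these compounds alone, until now the only readable step lay on the chain carbon on the core, and this result adds a first reading from the six-membered aromatic ring of carbon only, which the step of an at least 2.3-fold higher number from compound 2 to compound 3 (0.37 log units; beyond the scatter) could not supply. It is also the only step in the series with a plain number at both ends, because the other two compounds carry a limit rather than a number: the limit of > 50 uM in this assay, at which 2 of the 4 values shown sit.

A single methyl at a single ring position says nothing about other positions on that ring, or about other groups there, such as a carboxylic acid, an amine or a trifluoromethyl. From the compounds shown here alone, whether the same methyl would matter on compound 1 or compound 3 also stays open, since each of those compounds stands at a limit and not at a number.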